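The compounds below may be only part of what the source reports. "The series", "measured", "known", "first", "only" and "open" are said of these compounds alone.

Measured so far:
Compound 1, `CC[C@H](Nc1nc(NCc2ccccn2)c2ncn(C(C)C)c2n1)C(O)C(C)(C)C`: 47000 nM
Compound 2, `CC[C@H](Nc1nc(NCc2ccccn2)c2ncn(C(C)C)c2n1)C(C)O`: 15500 nM
Compound 3, `CC[C@@H](Nc1nc(NCc2ccccn2)c2ncn(C(C)C)c2n1)C(C)O`: 20000 nM

In a functional assay on CH1 cells (Homo sapiens) for inhibition, read by sulforhodamine B assay, with a stated time of 96 h (on this read-out lower numbers stand for stronger inhibition of growth and higher numbers for weaker inhibition of growth), compound 1 gives 47000 nM, the highest of the three numbers; compound 3 sits nearest to it and compound 2 furthest from it, both beyond the scatter. The change from compound 1 to compound 4, `CCC(O)[C@@H](CC)Nc1nc(NCc2ccccn2)c2ncn(C(C)C)c2n1`, is 1-ethyl-2-hydroxybutyl in place of 1-ethyl-2-hydroxy-3,3-dimethylbutyl on a nitrogen on an aromatic ring. Among the compounds with values here, two measured steps bear on this change. The first, a 3.0-fold lower number from compound 1 to compound 2 (0.48 log units; beyond the scatter), trims the same side chain more deeply than the step to compound 4 does. The second, a 2.4-fold lower number from compound 1 to compound 3 (0.37 log units; beyond the scatter), makes the same trimming on the other configuration at the carbon bearing the hydroxyl group. The difference between compound 2 and compound 3, a 1.3-fold higher number from compound 2 to compound 3 (0.11 log units; within the scatter), lies within the scatter, and is noted alongside (the fact that one of compounds 2 and 3 is drawn with a defined configuration and the other without, at the place where they differ). Since compound 4 removes the two methyl groups of the tert-butyl but keeps an ethyl in their place, the expected step is a modest lowering of the number, somewhat smaller than or similar to the two measured steps: the step from compound 1 to compound 4 is estimated as a 2.1-fold lower number from compound 1 to compound 4 (0.33 log units; beyond the scatter). Compound 4 is therefore expected to give about 22000 nM in this assay, within the range from 11000 nM to 45000 nM.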

Compound 4, concentration for 50% growth inhibition: 26000 nM
The estimate for compound 4 lay 1.2-fold (0.07 log units) below the measured number; the range from low to high includes it.
By their numbers in this assay, from the lowest: compounds 2, 3, 4 and 1 (each within the scatter of the next, the first and the last beyond it).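

The step to 1-ethyl-2-hydroxybutyl on this nitrogen, a 1.8-fold lower number from compound 1 to compound 4 (0.26 log units; within the scatter), stays inside the scatter, whereas the two more deeply trimmed side chains had moved beyond it from compound 1. Compound 4 also cannot be separated from either of those shorter-chain compounds, as the two remaining steps show: a 1.3-fold higher number from compound 3 to compound 4 (0.11 log units; within the scatter), and a 1.7-fold higher number from compound 2 to compound 4 (0.22 log units; within the scatter). The four compounds therefore read as a shallow gradient rather than a sharp break at this position: only compound 1 set against compound 2 or compound 3 lies beyond the scatter, and compound 4 sits within the scatter of all three.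

The compounds shown leave open how an amine, a carboxylic acid or a longer chain on this side chain would compare, since every side chain here is a hydroxylated saturated chain. It also remains unsettled whether the configuration at the carbon bearing the hydroxyl group matters in compound 4, as the pair that might speak to this gives no firm reading: the fact that one of compounds 2 and 3 is drawn with a defined configuration and the other without, at the place where they differ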